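Swapping a Hexyl Chain for a Methoxyphenyl Ring

The source may report more compounds than this note shows. Statements on the series, on what has been measured and on what is new or still open speak of the compounds shown alone.

Three measured compounds share one core and differ only in the group attached through an oxygen on a saturated carbon. Compound 1 `Cc1nn(-c2ncnc3nc[nH]c23)c2c1C(OCc1ccccc1Cl)CC(=O)N2` carries a 2-chlorophenyl there; in a functional assay on HEK293 cells for agonist activity at G-protein coupled receptor 39 (Homo sapiens), read by scintillation proximity assay and inositol phosphate accumulation, with a stated time of 75 min (on this read-out higher numbers stand for an effect only at larger amounts of compound and lower numbers for an effect already at smaller amounts), compound 1 gives 47 nM. Compound 2 `Cc1cc(C)n(CCOC2CC(=O)Nc3c2c(C)nn3-c2ncnc3nc[nH]c23)n1` carries a (3,5-dimethyl-1H-pyrazol-1-yl)methyl, and in this assay compound 2 gives 2000 nM. Compound 3 `CCCCCCCCOC1CC(=O)Nc2c1c(C)nn2-c1ncnc2nc[nH]c12` carries a heptyl; in this assay compound 3 gives 388 nM, the second highest of the three numbers, with an 8.3-fold higher number from compound 1 to compound 3 (0.92 log units; beyond the scatter) and a 5.2-fold lower number from compound 2 to compound 3 (0.71 log units; beyond the scatter).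

Compound 4 `COc1ccc(CCOC2CC(=O)Nc3c2c(C)nn3-c2ncnc3nc[nH]c23)cc1` differs from compound 3 in one place: 4-methoxyphenyl in place of hexyl on a saturated chain carbon, two bonds along the chain from an oxygen on a saturated carbon. Within the data shown here, two steps bear on this. Replacing a ring two bonds along the chain from the oxygen with hexyl gave a 5.2-fold lower number from compound 2 to compound 3 (0.71 log units; beyond the scatter), while replacing a ring bound directly to the chain carbon with a chain gave an 8.3-fold higher number from compound 1 to compound 3 (0.92 log units; beyond the scatter). Compound 4 puts an aromatic ring at the more distant position, so a higher number than for compound 3 is expected, though a smaller rise than the pyrazolyl produced, an expected 1.5-fold higher number from compound 3 to compound 4 (0.19 log units; within the scatter). Compound 4 is estimated at 600 nM in this assay, within 150 nM to 2500 nM.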

Compound 4, half-maximal effective concentration: 70 nM
Beside the measured number, compound 4's estimate is 8.6-fold (0.93 log units) above it; measured number outside the range, below it.
By their numbers in this assay, from the lowest: compounds 1 and 4 (each within the scatter of the next); then compound 3; then compound 2.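

Changing the group at this place gave a 5.5-fold lower number from compound 3 to compound 4 (0.74 log units; beyond the scatter) in this assay, and replacing 3,5-dimethyl-1H-pyrazol-1-yl gave a 29-fold lower number from compound 2 to compound 4 (1.46 log units; beyond the scatter), so a ring two bonds along the chain from the oxygen does not by itself push the number up: the outcome depends on which ring it is. The third step, a 1.5-fold higher number from compound 1 to compound 4 (0.17 log units; within the scatter), lies within the scatter, so 4-methoxybenzyl and 2-chlorophenyl on the chain carbon bound to the oxygen cannot be told apart here. Nothing shown explains why these rings behave so differently.

Going by these compounds, it remains open how much of the result belongs to the methoxy group and how much to the ring itself, a question that a plain phenyl, or a 4-hydroxyphenyl, at the same place would address. Also open, on these data alone, is whether a pyridine ring would follow 4-methoxyphenyl or the pyrazole.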